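From Propyl to Cyclopentyloxy on a Carbonyl Carbon

A few compounds are considered here, and "the series" means these few. Any claim that something is new, unique, unknown or untested is made for them only; others in the source may bear on it.

Within the data shown here, compound 1 `CCCC(=O)C1=C(C)NC(=O)NC1c1ccco1` gives 807 nM in an assay on membranes from HEK293 cells for displacement of a labelled ligand from adenosine receptor A2b (Homo sapiens), read by scintillation counting, with a stated time of 30 min (a lower number here means a stronger inhibitor, a higher number a weaker inhibitor), the lower of the two numbers measured so far. Compound 2 `CC1=C(c2ncc(C)o2)C(c2ccco2)NC(=O)N1` gives 905 nM in this assay, and the step of a 1.1-fold higher number from compound 1 to compound 2 (0.05 log units; within the scatter) stays within the scatter. Compound 3 `CC1=C(C(=O)OC2CCCC2)C(c2ccco2)NC(=O)N1` carries cyclopentyloxy in place of propyl on a carbonyl carbon. Among the measured compounds shown here, the only measured step replaces the whole propylcarbonyl of compound 1 rather than the propyl alone, so no firm guide exists; a step beyond the scatter is not expected in this assay. Compound 3 is therefore estimated at 800 nM, between 300 nM and 2500 nM, an expected step of a 1.0-fold lower number from compound 1 to compound 3 (0.00 log units; within the scatter).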

Compound 3, inhibition constant: 577 nM
Compound 3: the middle estimate sits 1.4-fold (0.14 log units) above what was measured, and the stated range covers the measured number.
By their numbers in this assay, from the lowest: compounds 3, 1 and 2 (each within the scatter of the next).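

On this carbonyl carbon, whose other neighbour is the double-bonded ring carbon, cyclopentyloxy brings in a five-membered non-aromatic ring of carbon only and a hydrogen-bond acceptor that propyl lacks, and this assay still shows only a 1.4-fold lower number from compound 1 to compound 3 (0.15 log units; within the scatter). Unlike the earlier step, which replaced the whole propylcarbonyl, this one keeps the carbonyl and alters only the group on it, so this place tolerates a larger group with a ring without leaving the scatter.

Going by these compounds, whether an amine or a longer chain on this carbonyl carbon would give a step beyond the scatter stays open. No evidence bearing on this result is at hand.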